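From Fluoro to Dimethylamino on an Aromatic Carbon

This account rests on a few compounds, and the source may have more. Where it says the series, first, only, none or still open, it means among the compounds named here.

In a functional assay on A-375 cells (Homo sapiens) for antiproliferative activity, read by sulforhodamine B assay, with a stated time of 48 h (on this read-out higher numbers stand for weaker inhibition and lower numbers for stronger inhibition), compound 1 (`CN(C)c1ccc2c(c1)OC(N)=C(C#N)C2c1cccc2c(Br)cccc12`) gives 140 nM, compound 2 (`COc1ccc(C2C(C#N)=C(N)Oc3cc(N(C)C)ccc32)c2ccccc12`) gives 440 nM and compound 3 (`CN(C)c1ccc2c(c1)OC(N)=C(C#N)C2c1ccc(F)c2ccccc12`) gives 280 nM. Compound 3 thus lies within the usual scatter of both other compounds. Compound 4 (`CN(C)c1ccc2c(c1)OC(N)=C(C#N)C2c1ccc(N(C)C)c2ccccc12`) has not yet been measured. It carries dimethylamino in place of fluoro on an aromatic carbon. Going by the values given here, one measured step bears on this swap, also a change of the group at an aromatic carbon: a 1.6-fold lower number from compound 2 to compound 3 (0.20 log units; within the scatter). That step stayed within the scatter, so no shift beyond the scatter is expected here. The estimated step is a 1.3-fold higher number from compound 3 to compound 4 (0.10 log units; within the scatter). For compound 4, the expected value is 350 nM, with an estimated range of 130 nM to 950 nM.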

Compound 4, half-maximal inhibitory concentration: 80 nM
Compound 4: middle estimate off by 4.4-fold (0.64 log units), on the high side; measured number outside the range, below it.
By their numbers in this assay, from the lowest: compounds 4, 1, 3 and 2 (each within the scatter of the next, the first and the last beyond it).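

At this place, para to a large group, the choice of group clearly matters in this assay: dimethylamino gives a 3.5-fold lower number from compound 3 to compound 4 (0.54 log units; beyond the scatter) and a 5.5-fold lower number from compound 2 to compound 4 (0.74 log units; beyond the scatter), whereas methoxy and fluoro stayed within the scatter of each other, with a 1.6-fold lower number from compound 2 to compound 3 (0.20 log units; within the scatter). Of these three groups, only dimethylamino stands apart from the other two. No measurement shown gives a reason for this shift.

As far as these compounds go, it remains open whether the stronger inhibition needs the methyl groups on the nitrogen. A plain amine, methylamino or a pyrrolidine ring at this place would test that.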